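Propargyl amine swap on the sulfonyl core

This account rests on a few compounds, and the source may have more. Where it says the series, first, only, none or still open, it means among the compounds named here.

In an assay on HEK293 cells for displacement of a labelled ligand from 5-hydroxytryptamine receptor 6 (Homo sapiens), read by scintillation counting, with a stated time of 1 h (on this read-out lower numbers stand for stronger inhibition and higher numbers for weaker inhibition), compound 2 `C[C@H](NCc1ccc(OCCCCCN2CCN(c3cccc4c3ccn4S(=O)(=O)c3ccccc3)CC2)cc1)C(N)=O` gives 65 nM, the lowest of the three numbers; compound 3 `C#CCN(C)Cc1ccc(OCCCCCCN2CCN(c3cccc4c3ccn4Cc3cccc(Cl)c3)CC2)cc1` gives 137 nM and compound 1 `C[C@H](NCc1ccc(OCCCCCCN2CCN(c3cccc4c3ccn4Cc3cccc(Cl)c3)CC2)cc1)C(N)=O` gives 340 nM. Compound 4 `C#CCN(C)Cc1ccc(OCCCCCN2CCN(c3cccc4c3ccn4S(=O)(=O)c3ccccc3)CC2)cc1` differs from compound 2 by methyl(propargyl)amino in place of (1-carbamoylethyl)amino on a saturated chain carbon bound to an aromatic carbon. Within the data shown here, one measured step bears on this change, on the core of compound 1 rather than that of compound 2: a 2.5-fold lower number from compound 1 to compound 3 (0.39 log units; beyond the scatter). Among the measured compounds shown here, with only that single precedent, the same change on compound 2 is expected to give a step of similar size in this assay, toward a lower number, estimated as a 2.5-fold lower number from compound 2 to compound 4 (0.40 log units; beyond the scatter). Compound 4 is therefore expected at about 26 nM, with a range from 12 nM to 60 nM.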

Compound 4, inhibition constant: 38 nM
The estimate for compound 4 lay 1.5-fold (0.16 log units) below the measured number, within the range that was stated.
By their numbers in this assay, from the lowest: compounds 4 and 2 (each within the scatter of the next); then compound 3; then compound 1.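

On the core of compound 2, the change gives a 1.7-fold lower number from compound 2 to compound 4 (0.23 log units; within the scatter), so this read-out does not separate the two groups here, whereas on the core of compound 1 the step lay beyond the scatter. The hydrogen-bond donors and defined stereocentre of (1-carbamoylethyl)amino are not required to keep the number at this level on this core. The change also reads alike on both cores: the same change on two cores in this assay, a 2.5-fold lower number (0.39 log units; beyond the scatter) from compound 1 to compound 3 and a 1.7-fold lower number (0.23 log units; within the scatter) from compound 2 to compound 4, 1.5-fold (0.16 log units) apart, within the scatter of two such steps

As far as these compounds go, whether the triple bond contributes remains open. Methyl(propyl)amino at this place would test that directly.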